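This account rests on a few compounds, and the source may have more. Where it says the series, first, only, none or still open, it means among the compounds named here.

Compound 2 `COc1ccc(C2CC(c3cc(Cl)c(C)cc3O)=NN2c2ccc(S(N)(=O)=O)cc2)cc1OC` and compound 1 `Cc1cc(O)c(C2=NN(c3ccc(S(N)(=O)=O)cc3)C(c3ccccc3O)C2)cc1Cl` share a core. In a functional assay on OVCAR-3 cells (Homo sapiens) for antiproliferative activity, with a stated time of 48 h (on this read-out higher numbers stand for weaker inhibition of growth and lower numbers for stronger inhibition of growth), compound 2 gives 3370 nM, and compound 1 gives 1810 nM; the two lie within the scatter of each other, as a 1.9-fold higher number from compound 1 to compound 2 (0.27 log units; within the scatter) shows. Compound 3 `COc1ccc(C2CC(c3cc(Cl)c(C)cc3O)=NN2c2ccc(S(N)(=O)=O)cc2)c(OC)c1OC` differs from compound 2 by methoxy in place of hydrogen on an aromatic carbon. Going by the values given here, the one step measured on that ring, a 1.9-fold higher number from compound 1 to compound 2 (0.27 log units; within the scatter), exchanged the whole group and still stayed within the scatter, so adding a single methoxy is expected to give no step beyond the scatter in this assay. Compound 3 is therefore estimated at 3500 nM, within 1500 nM to 8000 nM, meaning a 1.0-fold higher number from compound 2 to compound 3 (0.02 log units; within the scatter).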

Compound 3, concentration for 50% growth inhibition: 2190 nM
Beside the measured number, compound 3's estimate is 1.6-fold (0.20 log units) above it; measured number inside the range.
By their numbers in this assay, from the lowest: compounds 1, 3 and 2 (each within the scatter of the next).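

Placed on an aromatic carbon ortho to a large group, methoxy in place of hydrogen gives in this assay a 1.5-fold lower number from compound 2 to compound 3 (0.19 log units; within the scatter) and so adds no step beyond the scatter at this position. The 2,3,4-trimethoxyphenyl group in place of 2-hydroxyphenyl gives a 1.2-fold higher number from compound 1 to compound 3 (0.08 log units; within the scatter) and thus also stays within the scatter, so the three groups shown on that saturated ring carbon cannot be told apart in this read-out. Nothing available explains this result. As far as these compounds go, whether an amine or a carboxylic acid on this ring would give a step beyond the scatter remains open.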